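The source may hold more compounds than are shown below. What is called first, only, known or untested is meant among the compounds shown, and "the series" means these compounds.

Of the compounds shown here, three built on a shared core have been measured in a functional assay on MCF7 cells (Homo sapiens) for antiproliferative activity, read by MTT assay, with a stated time of 48 h; a higher number here means a weaker inhibitor, a lower number a stronger inhibitor. Compound 1 `COc1ccc2nc(NC(c3cn(-c4ccccc4)nc3-c3cccc([N+](=O)[O-])c3)c3c(O)ccc4ccccc34)sc2c1` gives 26800 nM in this assay, compound 2 `COc1ccc2nc(NC(c3cn(-c4ccccc4)nc3-c3cccc(I)c3)c3c(O)ccc4ccccc34)sc2c1` gives 20000 nM, and compound 3 `Oc1ccc2ccccc2c1C(Nc1nc2ccc(Cl)cc2s1)c1cn(-c2ccccc2)nc1-c1ccc(I)cc1` gives 65000 nM, the highest of the three. Compound 1 differs from compound 2 by nitro in place of iodo on an aromatic carbon, and that gave a 1.3-fold higher number from compound 2 to compound 1 (0.13 log units; within the scatter). Compound 4 `O=[N+]([O-])c1ccc(-c2nn(-c3ccccc3)cc2C(Nc2nc3ccc(Cl)cc3s2)c2c(O)ccc3ccccc23)cc1` is not yet measured; it differs from compound 3 by nitro in place of iodo on an aromatic carbon. This is the same kind of change, though the surroundings differ: in the earlier pair the group sits meta to a large group, here para to a large group. How the core of compound 3 differs from that of compound 2 is not broken down here. From compound 3 to compound 4 the step in this assay is expected to be a 1.2-fold higher number from compound 3 to compound 4 (0.09 log units; within the scatter), because the matching change gave a 1.3-fold higher number from compound 2 to compound 1 (0.13 log units; within the scatter). Compound 4 is therefore expected to give about 80000 nM, likely between 35000 nM and 180000 nM.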

Compound 4, half-maximal inhibitory concentration: 38600 nM
Beside the measured number, compound 4's estimate is 2.1-fold (0.32 log units) above it; measured number inside the range.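

In this assay, nitro in place of iodo gives a 1.7-fold lower number from compound 3 to compound 4 (0.23 log units; within the scatter), a step that stays within the usual scatter, as did a 1.3-fold higher number from compound 2 to compound 1 (0.13 log units; within the scatter). Within what this assay can resolve, the change behaves alike on the two cores: the same change on two cores in this assay, a 1.3-fold higher number (0.13 log units; within the scatter) from compound 2 to compound 1 and a 1.7-fold lower number (0.23 log units; within the scatter) from compound 3 to compound 4, 2.3-fold (0.35 log units) apart, within the scatter of two such steps This shows only that the swap makes no clear difference on these two cores; with one pair per core, it cannot reveal a small real effect or show that the result holds on other cores.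

As far as these compounds go, it remains open whether another group in this place, such as an amine or a carboxylic acid, would shift the number beyond the scatter. The effect of the core difference is also open, as no pair shown differs only there.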